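One Phenyl Swap After a Flat Measured Step

The source may hold more compounds than are shown below. What is called first, only, known or untested is meant among the compounds shown, and "the series" means these compounds.

Among the compounds with values here, in a functional assay on HepG2 cells (Homo sapiens) for cytotoxicity, read by MTT assay, with a stated time of 24 h (a lower number here means a stronger inhibitor, a higher number a weaker inhibitor), compound 2 (`CC(=O)Nc1ccc(Oc2cccc3c(NC(=O)Nc4ccccc4)cccc23)cc1`) gives 258 nM and stands level with compound 1 (`CC(=O)Nc1ccc(Oc2cccc3c(NC(=O)Nc4cccc(C(F)(F)F)c4)cccc23)cc1`) at 258 nM on the numbers so far. The next structure, compound 3 (`CC(=O)Nc1ccc(Oc2cccc3c(NC(=O)Nc4ccc(Cl)c(C(F)(F)F)c4)cccc23)cc1`), carries 4-chloro-3-(trifluoromethyl)phenyl in place of phenyl on an amide-type nitrogen. A step here means the change in the read-out between two compounds that differ in one place. Within the data shown here, only one measured step bears on this swap: no change at the digits printed from compound 1 to compound 2 (within the scatter) with hydrogen in place of trifluoromethyl on an aromatic carbon. That step lies within the scatter. Among the measured compounds shown here, no measured step covers the chloro part of the new group, so the guidance is thin and the range must stay wide. With that single step as the guide, no step beyond the scatter is expected in this assay in either direction. The expected change is a 1.1-fold lower number from compound 2 to compound 3 (0.03 log units; within the scatter) on this estimate. The estimate for compound 3 is 240 nM (range 90 nM to 650 nM).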

Compound 3, half-maximal inhibitory concentration: 258 nM
For compound 3 the middle estimate is 1.1-fold (0.03 log units) below the measured one; the range from low to high includes it.
By their numbers in this assay, from the lowest: compounds 1, 2 and 3 (each within the scatter of the next).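

In this assay the full replacement of phenyl by 4-chloro-3-(trifluoromethyl)phenyl on the amide-type nitrogen leaves the read-out flat (no change at the digits printed from compound 2 to compound 3 (within the scatter)), and chloro in place of hydrogen, taken alone on the trifluoromethyl compound, does the same (no change at the digits printed from compound 1 to compound 3 (within the scatter)). Within the data shown here, this is the first view of chloro on this ring, and it extends the earlier result: the plain phenyl, the trifluoromethyl-bearing ring and the ring with both trifluoromethyl and chloro all sit within the scatter of one another, so these three compounds cannot be put in any order. Nothing available explains why these changes leave the read-out flat.

From the compounds shown here alone, what remains open is whether this tolerance extends beyond halogen-containing groups to quite different ones on the same ring, such as an amine, a carboxylic acid or a methoxy group, and how a ring carrying chloro without trifluoromethyl would read. The three compounds also share everything else in their structures, so they say nothing about how the read-out responds to a change elsewhere, such as replacing the acetyl group on the far ring.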